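A few compounds are considered here, and "the series" means these few. Any claim that something is new, unique, unknown or untested is made for them only; others in the source may bear on it.

Of the compounds shown here, two built on the same core have been measured in an assay on membranes from HEK293 cells for displacement of a labelled ligand from adenosine receptor A2b (Homo sapiens), read by scintillation counting, with a stated time of 30 min, tested at 1 uM; on this read-out lower numbers stand for less inhibition and higher numbers for more inhibition at the one concentration tested (going by the name of the read-out). Compound 1, `CC1=C(C(N)=O)C(c2ccoc2)NC(=O)N1`, gives 6% in this assay. Compound 2, `CCNC(=O)C1=C(C)NC(=O)NC1c1ccoc1`, gives 2% in this assay. Within the data shown here, the only step available is a number 4 percentage points lower from compound 1 to compound 2 (within the scatter), so the two numbers sit within the usual scatter of each other, and both lie near the bottom of the scale; on what has been measured, compound 2 is not separated from compound 1.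

Compound 3, `CCSC(=O)C1=C(C)NC(=O)NC1c1ccoc1`, is the next member. Its difference from compound 2 is ethylsulfanyl in place of ethylamino on a carbonyl carbon. Among the measured compounds shown here, no measured step touches this kind of exchange; the one step known, a number 4 percentage points lower from compound 1 to compound 2 (within the scatter), concerns only the group on the amide-type nitrogen and was itself within the scatter. With both measured compounds close to zero and no change having moved the read-out, the expectation for compound 3 is a step of about a number 2 percentage points higher from compound 2 to compound 3 (within the scatter) in this assay, that is, none beyond the scatter. Compound 3 is therefore estimated at 4% in this assay, with a likely range from -6% to 16%.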

Compound 3, a percentage reported as inhibition, at one concentration (the size of the read-out at that concentration, not a potency): 1%
Beside the measured number, compound 3's estimate is 3 percentage points above it; the range from low to high includes it.
By their numbers in this assay, from the lowest: compounds 3, 2 and 1 (each within the scatter of the next).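

In this assay the atom joined to the carbonyl carbon has now been changed, whereas the earlier step touched only the group on an amide-type nitrogen: ethylsulfanyl in place of ethylamino gives a number 1 percentage points lower from compound 2 to compound 3 (within the scatter) and ethylsulfanyl in place of amino gives a number 5 percentage points lower from compound 1 to compound 3 (within the scatter) on the same carbonyl carbon. Sulfur thus replaces nitrogen at this place, and the hydrogen-bond donor and acceptor counts of the group change with it, yet compound 3 is not separated from compound 2 or from compound 1 on this read-out. No measurement on hand offers an explanation for this result.

As far as these compounds go, all three numbers lie close to the bottom of the scale at a single concentration, so it remains open whether any group on this carbonyl carbon can lift the read-out clear of the scatter. A carboxylic acid, an ethoxy group, a longer chain on the sulfur or the nitrogen, or a benzylamino group at this place could test that, and the furan-bearing side of the shared core has not been varied among the compounds shown.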